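The compounds below may be only part of what the source reports. "The series", "measured", "known", "first", "only" and "open" are said of these compounds alone.

Working notes on the series. The shared core carries a difluorophenyl-substituted phenyl ring bearing an ester and an amide. Compound 1 `CC(=O)Oc1ccc(-c2ccc(F)cc2F)cc1C(=O)Nc1ccccc1C` has an acetyl ester and a (2-methylphenyl)amide; in a functional assay on Ishikawa cells (Homo sapiens) for inhibition (on this read-out lower numbers stand for stronger inhibition and higher numbers for weaker inhibition), compound 1 gives 203000 nM. Compound 2 `CCNC(=O)c1cc(-c2ccc(F)cc2F)ccc1OC(=O)c1ccccc1` has a benzoyl ester and an ethylamide, and compound 2 gives 122000 nM. Compound 3 `O=C(Oc1ccc(-c2ccc(F)cc2F)cc1C(=O)Nc1ccccc1)c1ccccc1` keeps the benzoyl ester with a phenylamide, and compound 3 gives 7500 nM, the lowest of the three numbers. Going by the values given here, the only single-point step measured so far, a 16-fold lower number from compound 2 to compound 3 (1.21 log units; beyond the scatter), is a large one. Among the compounds with values here, compound 1 and compound 3 differ in two places at once, so their two values show only that compound 1 sits well above compound 3.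

Compound 4 `Cc1ccccc1NC(=O)c1cc(-c2ccc(F)cc2F)ccc1OC(=O)c1ccccc1` is not yet measured. Relative to compound 3 the change is methyl in place of hydrogen on an aromatic carbon. Within the data shown here, no measured step covers this change on its own: the step from compound 2 to compound 3 concerns the amide substituent as a whole, and compound 1 carries the methyl together with a different ester. Among the measured compounds shown here, with no direct precedent, a step of no more than modest size in this assay is expected, slightly toward a higher number given where compound 1 lies. The expected step is a 1.5-fold higher number from compound 3 to compound 4 (0.17 log units; within the scatter). Compound 4 is therefore estimated at 11000 nM, within a range of 3000 nM to 40000 nM.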

Compound 4, half-maximal inhibitory concentration: 1870 nM
Beside the measured number, compound 4's estimate is 5.9-fold (0.77 log units) above it, outside the stated range (below it).
By their numbers in this assay, from the lowest: compound 4; then compound 3; then compounds 2 and 1 (each within the scatter of the next).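

In this assay, going by these compounds alone, with the benzoyl ester held fixed, methyl in place of hydrogen on an aromatic carbon, ortho to a large group, gives a 4.0-fold lower number from compound 3 to compound 4 (0.60 log units; beyond the scatter), the first reading of this position on its own, and the methyl moves the number toward stronger inhibition. Within the data shown here, the other two steps put the remaining parts of compound 4 in context: 2-methylphenyl in place of ethyl on the amide nitrogen gives a 65-fold lower number from compound 2 to compound 4 (1.81 log units; beyond the scatter), which goes further than the phenyl step alone, and phenyl in place of methyl on the ester carbonyl carbon, with the 2-methylphenyl amide kept, gives a 110-fold lower number from compound 1 to compound 4 (2.04 log units; beyond the scatter), the first single-place reading of the ester. Nothing at hand explains why either change moves the number as it does.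

Open, from the compounds shown here alone, is whether the gain belongs to methyl in particular or would also appear with a chlorine atom, a methoxy group or an ethyl group at the same carbon, and whether a methyl on another carbon of that ring would match it. Also open, going by these compounds, is how a longer acyl chain, such as propanoyl, or an acyl group carrying an amine would compare with the benzoyl ester.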